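From Compound 1 to Compound 3: Exchanging One Side Group

The source may report more compounds than this note shows. Statements on the series, on what has been measured and on what is new or still open speak of the compounds shown alone.

For the measured compounds named here, in a functional assay on MT4 cells (Homo sapiens) for antiproliferative activity (on this read-out higher numbers stand for lower toxicity in this test and lower numbers for higher toxicity in this test), compound 1 (`Cc1cn(C2OC(CO[Si](C)(C)C(C)(C)C)C3(OS(=O)(=O)C=C3N)C2O[Si](C)(C)C(C)(C)C)c(=O)n(CCCNC(=O)[C@@H]2CCCN2C(=O)[C@H](C)N)c1=O`) gives 20000 nM, the lower of the two numbers so far, which makes it the more toxic of the pair in this test. Compound 2 (`Cc1cn(C2OC(CO[Si](C)(C)C(C)(C)C)C3(OS(=O)(=O)C=C3N)C2O[Si](C)(C)C(C)(C)C)c(=O)n(CCCNC(=O)[C@@H]2CCCN2C(=O)[C@@H](N)CC(=O)O)c1=O`) gives 69000 nM, and it differs from compound 1 by carboxy in place of hydrogen on a saturated chain carbon.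

Compound 3 (`Cc1cn(C2OC(CO[Si](C)(C)C(C)(C)C)C3(OS(=O)(=O)C=C3N)C2O[Si](C)(C)C(C)(C)C)c(=O)n(CCCNC(=O)[C@@H](N)C(C)C)c1=O`) has not yet been measured. Its difference from compound 1 is larger: 1-amino-2-methylpropyl in place of 1-((1-aminoethyl)carbonyl)pyrrolidin-2-yl on a carbonyl carbon. Going by the values given here, the new group sits on a carbonyl carbon, and the group it replaces is the one altered in compound 2. Among the compounds with values here, no measured step makes this exact exchange, so the evidence is thin. Within the data shown here, the only guide is compound 2, whose step a 3.5-fold higher number from compound 1 to compound 2 (0.54 log units; beyond the scatter) is modest, although beyond the usual scatter.

With so little to go on, no shift beyond the scatter is expected, and the estimated step is a 1.3-fold higher number from compound 1 to compound 3 (0.10 log units; within the scatter). For compound 3 the expected value is 25000 nM, with an estimated range from 10000 nM to 70000 nM.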

Compound 3, half-maximal cytotoxic concentration: 8200 nM
Estimate against measurement, compound 3: 3.0-fold (0.48 log units) above; measured number below the stated range.
By their numbers in this assay, from the lowest: compound 3; then compound 1; then compound 2.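

In this assay, the position on the carbonyl carbon turns out to tolerate a much smaller group: 1-amino-2-methylpropyl, with 5 heavy atoms and no ring, replaces 1-((1-aminoethyl)carbonyl)pyrrolidin-2-yl, with 10 heavy atoms and a five-membered non-aromatic ring, and this gives a 2.4-fold lower number from compound 1 to compound 3 (0.39 log units; beyond the scatter). A lower number here means higher toxicity in this test, so this exchange moves the read-out the opposite way from the carboxy change, which gave a 3.5-fold higher number from compound 1 to compound 2 (0.54 log units; beyond the scatter), and the side chain of compound 1 can therefore be altered to shift the number either up or down. No measurement shown here explains why the number falls.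

The exchange in compound 3 changes several things at once, including the ring, a carbonyl and the number of defined stereocentres, so the compounds shown cannot say which of these accounts for the step. Going by these compounds, it also remains open how the number would respond to a simple 1-aminoethyl group on the same carbonyl carbon, or to a longer chain ending in a carboxylic acid there.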